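The compounds below may be only part of what the source reports. "The series", "measured", "known", "first", "only" and "open" are said of these compounds alone.

Compound 1 `O/N=C(/Nc1ccc(F)c(F)c1)c1ccc2occc2c1`, compound 2 `O/N=C(/Nc1ccc(Cl)c(F)c1)c1ccc2occc2c1` and compound 3 `O/N=C(/Nc1cccc(F)c1)c1ccc2oc(-c3ccccc3)cc2c1` have been measured in an assay on tissue (HeLa cells) for inhibition of Indoleamine 2,3-dioxygenase 1 (Homo sapiens), read by spectrophotometry (a lower number here means a stronger inhibitor, a higher number a weaker inhibitor), while compound 4 `O/N=C(/Nc1cccc(Cl)c1)c1ccc2oc(-c3ccccc3)cc2c1` has not. In this assay compound 1 gives 14000 nM, compound 2 gives 10300 nM and compound 3 gives 10600 nM. The change from compound 1 to compound 2 is chloro in place of fluoro on an aromatic carbon, and it made a step of a 1.4-fold lower number from compound 1 to compound 2 (0.13 log units; within the scatter). The difference between the core of compound 1 and the core of compound 3 is not broken down here. The change from compound 3 to compound 4 is chloro in place of fluoro on an aromatic carbon. This is the same kind of change as that from compound 1 to compound 2, but not the same: in the earlier pair the place is ortho to a fluoro group and para to a large group, whereas in the later pair it is meta to a large group. Because the earlier step of a 1.4-fold lower number from compound 1 to compound 2 (0.13 log units; within the scatter) stayed within the scatter, a similarly small movement is expected for compound 4, with an estimated step of a 1.3-fold lower number from compound 3 to compound 4 (0.12 log units; within the scatter). Compound 4 is therefore expected to give about 8000 nM in this assay, most likely between 3000 nM and 20000 nM.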

Compound 4, half-maximal inhibitory concentration: 10800 nM
Compound 4: middle estimate off by 1.4-fold (0.13 log units), on the low side; measured number inside the range.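

In this assay, chloro in place of fluoro on the core of compound 3 gave a 1.0-fold higher number from compound 3 to compound 4 (0.01 log units; within the scatter), and set beside the earlier step, the change carries from one core to the other with no difference that can be told apart: the same change on two cores in this assay, a 1.4-fold lower number (0.13 log units; within the scatter) from compound 1 to compound 2 and a 1.0-fold higher number (0.01 log units; within the scatter) from compound 3 to compound 4, 1.4-fold (0.14 log units) apart, within the scatter of two such steps. Both steps are small, so the two pairs agree only in that this change left the number within the scatter on both cores; they do not show that the change has any effect of its own on either core. The place of the change also differs between the two pairs, so core and place are not separated here, and two pairs set no rule for other cores in the series.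

On these data alone, it remains open whether another group at this place, such as trifluoromethyl, methoxy or nitrile, would move the number beyond the scatter. As far as these compounds go, it is equally open whether an amine or a carboxylic acid on either core would do so.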